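One More Methyl on Compound 3

A few compounds are considered here, and "the series" means these few. Any claim that something is new, unique, unknown or untested is made for them only; others in the source may bear on it.

Of the compounds shown here, three have so far been measured in an ADME assay on MDCKII-LE cells (Canis lupus familiaris) for permeability; on this read-out lower numbers stand for lower permeability and higher numbers for higher permeability. Compound 1 `Cc1ccc(Oc2cc(C(=O)Nc3cnc(C)cn3)cc3oc(C)cc23)cc1` gives 0.3 10^-6 cm/s, and compound 2 `Cc1cnc(NC(=O)c2cc(Oc3ccc(C#N)cc3)c3cc(C)oc3c2)cn1` gives 1.5 10^-6 cm/s. Compound 3 `Cc1cc2c(Oc3cnc(C(=O)N4CC(C)C4)cn3)cc(C(=O)Nc3cnccn3)cc2o1` gives 14.9 10^-6 cm/s, the highest of the three numbers and clear of the other two by more than the usual scatter.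

Compound 4 `Cc1cc2c(Oc3cnc(C(=O)N4CC(C)(C)C4)cn3)cc(C(=O)Nc3cnccn3)cc2o1`, not yet measured, differs from compound 3 in one place: methyl in place of hydrogen on a saturated ring carbon. This is methyl in place of hydrogen on a saturated ring carbon, which turns 3-methylazetidin-1-yl into 3,3-dimethylazetidin-1-yl.

Going by the values given here, only one measured step compares two compounds that differ in a single place: a 5.0-fold higher number from compound 1 to compound 2 (0.70 log units; beyond the scatter). That modest step, beyond the scatter, puts cyano in place of methyl on an aromatic carbon. Among the compounds with values here, it involves different groups on a different kind of carbon, so it offers little guidance here, and no measured step covers the new methyl. No shift beyond the scatter is therefore expected in this assay, in either direction. The estimated step is a 1.1-fold lower number from compound 3 to compound 4 (0.06 log units; within the scatter). For compound 4 the expected value is 13 10^-6 cm/s, with an estimated range from 6 10^-6 cm/s to 28 10^-6 cm/s.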

Compound 4, apparent permeability: 7.7 10^-6 cm/s
Compound 4: the middle estimate sits 1.7-fold (0.23 log units) above what was measured; the measured number falls inside the stated range.
By their numbers in this assay, from the lowest: compound 1; then compound 2; then compounds 4 and 3 (each within the scatter of the next).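

In this assay, the change from 3-methylazetidin-1-yl to 3,3-dimethylazetidin-1-yl gives a 1.9-fold lower number from compound 3 to compound 4 (0.29 log units; within the scatter). Going by these compounds alone, this is the first measured step at this saturated ring carbon, two ring bonds from the ring nitrogen, and it shows that adding a methyl here, a group with no hydrogen-bond donors or acceptors, leaves the number within the usual scatter of repeated measurements, so the two compounds cannot be told apart on this read-out. No separate measurement bears on this result, so the data give no explanation for it.

As far as these compounds go, this single pair covers only a methyl, so it remains open whether a longer chain such as ethyl, a hydroxyl group or an amine on the same ring carbon would also stay within the scatter or would shift the number beyond it. From the compounds shown here alone, it is also open whether the same added methyl would behave this way with a different group on the other side of the carbonyl or on a different core, as one step cannot establish a general rule for this position.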